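A few compounds are considered here, and "the series" means these few. Any claim that something is new, unique, unknown or untested is made for them only; others in the source may bear on it.

Measured compounds:
compound 1, `O=c1[nH]cc(S(=O)(=O)Nc2cccc(-c3cn(-c4ccccc4)nn3)c2)c(=O)[nH]1`, gives 17200 nM in a functional assay on SGC-7901 cells (Homo sapiens) for antiproliferative activity, read by MTT assay, with a stated time of 24 h; on this read-out higher numbers stand for weaker inhibition and lower numbers for stronger inhibition;
compound 2, `Cc1ccccc1-n1cc(-c2cccc(NS(=O)(=O)c3c[nH]c(=O)[nH]c3=O)c2)nn1`, gives 9230 nM;
compound 3, `O=c1[nH]cc(S(=O)(=O)Nc2cccc(-c3cn(-c4ccccc4F)nn3)c2)c(=O)[nH]1`, gives 16000 nM.

Compound 3 has the second highest of the three numbers. Its nearest neighbour is compound 1, at a 1.1-fold lower number from compound 1 to compound 3 (0.03 log units; within the scatter), and its furthest is compound 2, at a 1.7-fold higher number from compound 2 to compound 3 (0.24 log units; within the scatter); both gaps fall within the scatter, so no order among the three can be read from them.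

Compound 4, `O=c1[nH]cc(S(=O)(=O)Nc2cccc(-c3cn(-c4ccc(F)cc4)nn3)c2)c(=O)[nH]1`, differs from compound 3 by 4-fluorophenyl in place of 2-fluorophenyl on an aromatic nitrogen. Going by the values given here, two measured steps touch the same ring: from compound 1 to compound 3, where a fluoro entered in place of hydrogen, at a 1.1-fold lower number from compound 1 to compound 3 (0.03 log units; within the scatter), and from compound 2 to compound 3, at a 1.7-fold higher number from compound 2 to compound 3 (0.24 log units; within the scatter), each within the scatter. Moving the fluoro to another position on the same ring is therefore expected to give no step beyond the scatter in this assay, and the expected step is a 1.1-fold lower number from compound 3 to compound 4 (0.03 log units; within the scatter). For compound 4 the estimated value is 15000 nM, with a range from 7000 nM to 35000 nM.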

Compound 4, half-maximal inhibitory concentration: > 20000 nM
Compound 4 gave a limit, no number; the forecaster's own chance of this, stated with the estimate: 5%; middle value at least 1.3-fold (0.12 log units) away from the limit.
By their numbers in this assay, from the lowest: compounds 2, 3 and 1 (each within the scatter of the next). At a limit, above all of these: compound 4.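

Compound 4 gave a limit in this assay, not a number: the limit of > 20000 nM in this assay, at which 1 of the 4 values shown sits. At the aromatic nitrogen, 4-fluorophenyl in place of 2-methylphenyl gives the only step shown that lies beyond the scatter, an at least 2.1-fold higher number from compound 2 to compound 4 (0.33 log units; beyond the scatter), whereas every step among the earlier compounds lay within it, so this position can now be seen to register a change of group. The two other new steps, an at least 1.2-fold higher number from compound 3 to compound 4 (0.09 log units; that floor lies within the scatter) and an at least 1.1-fold higher number from compound 1 to compound 4 (0.06 log units; that floor lies within the scatter), have floors within the scatter, so the size of neither the move from 2-fluorophenyl to 4-fluorophenyl nor the change from the unsubstituted phenyl can be read.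

The compounds shown leave open how far above its limit compound 4 lies. They also leave open how a methoxy group or an amine on the same phenyl ring would read.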